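This account rests on a few compounds, and the source may have more. Where it says the series, first, only, none or still open, it means among the compounds named here.

The series shares the core of compound 1 `CC/C(=C(/c1ccc(/C=C/C(=O)O)cc1)c1ccc2[nH]ncc2c1)c1ccccc1`. In a functional assay on MCF7 cells (Homo sapiens) for cytotoxicity, read by CellTiter-Glo, with a stated time of 5 days (on this read-out higher numbers stand for weaker inhibition and lower numbers for stronger inhibition), compound 1 gives 7.2 nM, compound 2 `CC/C(=C(/c1ccc(/C=C/C(=O)O)cc1)c1cnc2[nH]ncc2c1)c1ccccc1` gives 302 nM, and compound 3 `CC/C(=C(/c1ccc(/C=C/C(=O)O)cc1)c1ccc2[nH]nc(F)c2c1)c1ccccc1` gives 5 nM. Compound 3 shows the lowest of the three numbers; the nearest number is that of compound 1 and the furthest that of compound 2. The step of a 1.4-fold lower number from compound 1 to compound 3 (0.16 log units; within the scatter) lies within the scatter, whereas a 60-fold lower number from compound 2 to compound 3 (1.78 log units; beyond the scatter) lies well beyond it. Compound 4 `CC/C(=C(/c1ccc(/C=C/C(=O)O)cc1)c1cc2cn[nH]c2cc1Cl)c1ccccc1` differs from compound 3 by 6-chloro-1H-indazol-5-yl in place of 3-fluoro-1H-indazol-5-yl on a double-bonded chain carbon bound to an aromatic carbon and a double-bonded chain carbon. Among the measured compounds shown here, two measured steps bear on this change. The step of a 1.4-fold lower number from compound 1 to compound 3 (0.16 log units; within the scatter) shows that the fluoro of the 3-fluoro-1H-indazol-5-yl group hardly moves the number, so its loss is expected to cost little. For the measured compounds named here, the step of a 42-fold higher number from compound 1 to compound 2 (1.62 log units; beyond the scatter) shows that a change within the bicycle can be large, but it concerns a six-membered aromatic ring with one hetero atom in place of one of carbon only, and no measured pair covers the chloro of the 6-chloro-1H-indazol-5-yl group. In this assay a small step is therefore expected, a 3.0-fold higher number from compound 3 to compound 4 (0.48 log units; beyond the scatter), toward a higher number or none beyond the scatter. Compound 4 is estimated at 15 nM in this assay, within a range from 4 nM to 60 nM.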

Compound 4, half-maximal inhibitory concentration: 137 nM
Beside the measured number, compound 4's estimate is 9.1-fold (0.96 log units) below it, outside the stated range (above it).
By their numbers in this assay, from the lowest: compounds 3 and 1 (each within the scatter of the next); then compound 4; then compound 2.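

In this assay, the chloro of 6-chloro-1H-indazol-5-yl brings a large step, a 19-fold higher number from compound 1 to compound 4 (1.28 log units; beyond the scatter), while fluoro in place of hydrogen gave only a 1.4-fold lower number from compound 1 to compound 3 (0.16 log units; within the scatter), so a halogen on this group is not neutral in every place. The exchange of 3-fluoro-1H-indazol-5-yl for 6-chloro-1H-indazol-5-yl gives a 27-fold higher number from compound 3 to compound 4 (1.44 log units; beyond the scatter), and the change leaves only a modest difference from the weakest member of the series, a 2.2-fold lower number from compound 2 to compound 4 (0.34 log units; beyond the scatter). The data offer no measured explanation for this loss.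

On these data alone, whether the step belongs to chloro itself or to any group in that place remains open. Methyl or methoxy in place of the chloro of 6-chloro-1H-indazol-5-yl would separate these two readings.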